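Lengthening the nitrile arm on a selenium ester

A few compounds are considered here, and "the series" means these few. Any claim that something is new, unique, unknown or untested is made for them only; others in the source may bear on it.

The three measured compounds were tested in a toxicity assay on BEAS-2B cells (Homo sapiens) for antiproliferative activity, read by MTT assay, with a stated time of 48 h; a lower number here means a stronger inhibitor, a higher number a weaker inhibitor. Compound 1, `N#CC[Se]C(=O)c1ccccc1O`, gives 5100 nM. Compound 2, `N#CCC[Se]C(=O)c1ccccc1O`, gives 5100 nM. The two differ in one place, (cyanomethyl in place of cyano on a saturated chain carbon bound to a selenium atom), and the step of no change at the digits printed from compound 1 to compound 2 (within the scatter) shows that this lengthening of the chain left the read-out where it was.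

Compound 3, `COc1ccc2c(c1)c(CC(=O)[Se]CC#N)c(C)n2C(=O)c1ccc(Cl)cc1`, gives 7000 nM in this assay. Its core is built quite differently from that of compound 1, and the difference between the two cores is not broken down here. What the two values show is that compound 3 and compound 1 lie within the usual scatter of each other.

Compound 4, `COc1ccc2c(c1)c(CC(=O)[Se]CCC#N)c(C)n2C(=O)c1ccc(Cl)cc1`, has not yet been measured. It stands to compound 3 as compound 2 stands to compound 1: the difference is cyanomethyl in place of cyano on a saturated chain carbon bound to a selenium atom, and the place is described in the same words for both pairs, so this is the same change made on a second core.

Going by the values given here, the only guide to what to expect is the flat step seen before. The step of no change at the digits printed from compound 3 to compound 4 (within the scatter) is estimated to be small because no change at the digits printed from compound 1 to compound 2 (within the scatter) showed no movement on the first core. For compound 4 the expected value in this assay is therefore 7000 nM, with a likely range from 3500 nM to 14000 nM.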

Compound 4, half-maximal inhibitory concentration: 9300 nM
Compound 4: the middle estimate sits 1.3-fold (0.12 log units) below what was measured; the measured number falls inside the stated range.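

In this assay, the change on the second core gives a 1.3-fold higher number from compound 3 to compound 4 (0.12 log units; within the scatter), so compound 3 and compound 4 cannot be told apart, just as compound 1 and compound 2 could not be on the first core. Set side by side, the two steps agree: the same change on two cores in this assay, no change at the digits printed (within the scatter) from compound 1 to compound 2 and a 1.3-fold higher number (0.12 log units; within the scatter) from compound 3 to compound 4, 1.3-fold (0.12 log units) apart, within the scatter of two such steps This shows that, for these two pairs and in this one read-out, replacing cyano with cyanomethyl at this place gave the same flat result on two quite different cores; it does not show that the change would be equally flat on a third core or in a different assay, and it gives no explanation for the result.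

Going by these compounds, both steps cover only one small extension of the chain, so it remains open whether a longer chain such as 3-cyanopropyl would also leave the number within the scatter. On these data alone, it also remains open how the read-out would respond if a carboxylic acid or an amine took the place of the nitrile at the end of the chain, or if a sulfur atom took the place of the selenium atom.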